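Compound 4 against three cytotoxicity limits

The source may report more compounds than this note shows. Statements on the series, on what has been measured and on what is new or still open speak of the compounds shown alone.

Values in an ADME assay on Vero cells (Chlorocebus sabaeus) for cytotoxicity, read by MTT assay, with a stated time of 72 h; a lower number here means that less compound is tolerated, a higher number that more compound is tolerated:
compound 1 `NS(=O)(=O)c1ccc(N2N=C(c3ccc(O)cc3)CC2c2cn(-c3ccccc3)nc2-c2ccccc2)cc1` — > 160000 nM
compound 2 `NS(=O)(=O)c1ccc(N2N=C(c3ccc(F)cc3)CC2c2cn(-c3ccccc3)nc2-c2ccc(F)cc2)cc1` — > 753000 nM
compound 3 `Cc1ccc(C2=NN(c3ccc(S(N)(=O)=O)cc3)C(c3cn(-c4ccccc4)nc3-c3ccc(F)cc3)C2)cc1` — > 90600 nM
compound 4 `COc1ccc(C2=NN(c3ccc(S(N)(=O)=O)cc3)C(c3cn(-c4ccccc4)nc3-c3ccc(F)cc3)C2)cc1` — not yet measured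

Among the compounds with values here, every value so far is a limit of the assay rather than a read number. For compound 1 the value > 160000 nM is such a limit (the limit of > 160000 nM in this assay, at which 1 of the 3 values shown sits). Compound 2 likewise sits at a limit, > 753000 nM (the limit of > 753000 nM in this assay, at which 1 of the 3 values shown sits). Compound 3 stands at > 90600 nM, again a limit (the limit of > 90600 nM in this assay, at which 1 of the 3 values shown sits), so on what is shown compound 3 cannot be placed above or below either of the other two. Within the data shown here, the single step between measured compounds, a step that the two limits leave unreadable from compound 2 to compound 3, cannot be sized, both of its ends being limits.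

Compound 4 differs from compound 3 by methoxy in place of methyl on an aromatic carbon. Among the measured compounds shown here, no measured step bears on this change in a readable way; the only step available is the unreadable one just named. With three limits and no read number anywhere in the series, the expected step that the limit leaves unreadable from compound 3 to compound 4 is none beyond the scatter. Compound 4 is therefore estimated at about 150000 nM, within 40000 nM to 600000 nM, and most probably the assay will again report only a limit for compound 4.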

Compound 4, half-maximal cytotoxic concentration: > 53100 nM
Compound 4 gave a limit, no number; the forecaster's own chance of this, stated with the estimate: 70%; the middle value lies beyond the limit too.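

In this assay compound 4 gives > 53100 nM, which is a limit. The steps from compound 3 to compound 4 and from compound 2 to compound 4 therefore cannot be read, since both ends of each are limits. The compounds shown leave open where any of compounds 1 to 4 would give a read number, and whether methoxy, methyl or fluoro changes tolerance at all.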